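The compounds below may be only part of what the source reports. "The series", "measured", "known", "first", "only" and "open" are said of these compounds alone.

Measured so far in an ADME assay for permeability, using PAMPA, at pH 7.4 (on this read-out lower numbers stand for lower permeability and higher numbers for higher permeability), as follows
compound 1 `O=C(O)COc1cc(Cl)c(C(=O)Nc2cccc(-c3nc4ccccc4s3)c2)cc1[N+](=O)[O-]` gives < 1 10^-6 cm/s which is a limit of the assay and not a number
compound 2 `O=C(Nc1cccc(-c2nc3ccccc3s2)c1)c1cc([N+](=O)[O-])c(O)cc1Cl` gives 307 10^-6 cm/s as a number
compound 3 `O=C(Nc1cccc(-c2nc3ccccc3s2)c1)c1cc([N+](=O)[O-])ccc1Cl` gives 12 10^-6 cm/s as a number

Compound 3 holds the lower of the two actual numbers, the gap being a 26-fold lower number from compound 2 to compound 3 (1.41 log units; beyond the scatter) in this series. Compound 4 `Cc1c(NC(=O)c2cc([N+](=O)[O-])ccc2Cl)cccc1-c1nc2ccccc2s1` differs by methyl in place of hydrogen on an aromatic carbon and carries methyl in place of hydrogen on an aromatic carbon, ortho to a 1,3-benzothiazol-2-yl group. That gap and an at least 12-fold higher number from compound 1 to compound 3 (1.07 log units; beyond the scatter) are the nearest measured steps. Among the compounds with values here, both are large, yet they exchange hydroxy and carboxymethoxy for hydrogen, and no measured step brings in a methyl. Starting from compound 3 at 12 10^-6 cm/s in this assay no step beyond the scatter is expected. The estimated step is a 1.2-fold higher number from compound 3 to compound 4 (0.07 log units; within the scatter) and remains an expectation. For compound 4 the estimated value is 14 10^-6 cm/s with an expected range from 4 10^-6 cm/s to 40 10^-6 cm/s in this estimate.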

Compound 4, apparent permeability: "below limit of detection" (no number reported)
The entry for compound 4 holds no number; no gap can be computed for the estimate.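

Within the data shown here, compound 4 is reported as below the limit of detection, without a number, in this assay, so no step from compound 3 to compound 4 can be read. The compounds shown leave open how far methyl ortho to a 1,3-benzothiazol-2-yl group moves the read-out, and how the entry for compound 4 relates to the one limit shown in this assay: the limit of < 1 10^-6 cm/s in this assay, at which 1 of the 4 values shown sits.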